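Dropping an Aromatic Methyl: Expected Effect on Cytotoxicity

A few compounds are considered here, and "the series" means these few. Any claim that something is new, unique, unknown or untested is made for them only; others in the source may bear on it.

Measured compounds:
Compound 1, `CN(C)CCN1CCN(CC(=O)Nc2ccc(-c3nc4ccccc4o3)cc2)CC1`, which in a functional assay on A549 cells (Homo sapiens) for cytotoxicity, read by MTT assay, with a stated time of 24 h (a higher number here means a weaker inhibitor, a lower number a stronger inhibitor), gives 18700 nM.
Compound 2, `Cc1cc(-c2nc3ccccc3o2)ccc1NC(=O)CN1CCN(CCN(C)C)CC1`, which in this assay gives 30500 nM.
Compound 3, `Cc1cc(-c2nc3ccccc3o2)ccc1NC(=O)CN1CCN(CCCN(C)C)CC1`, which in this assay gives 22100 nM.

Compounds 2 and 3 carry different cores, and the difference between them is (dimethylamino)methyl in place of dimethylamino on a saturated chain carbon, two bonds along the chain from an amine nitrogen in a ring. That change gives a 1.4-fold lower number from compound 2 to compound 3 (0.14 log units; within the scatter). The change from compound 2 to compound 1 is hydrogen in place of methyl on an aromatic carbon, and it gives a 1.6-fold lower number from compound 2 to compound 1 (0.21 log units; within the scatter). All three numbers lie within the scatter of one another, so no order among them is claimed.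

Compound 4, `CN(C)CCCN1CCN(CC(=O)Nc2ccc(-c3nc4ccccc4o3)cc2)CC1`, has not yet been measured in this assay. It differs from compound 3 by hydrogen in place of methyl on an aromatic carbon, the same change at the same place as that from compound 2 to compound 1. The step of a 1.5-fold lower number from compound 3 to compound 4 (0.17 log units; within the scatter) is expected to be of like size to the earlier one. That expectation rests on the step of a 1.6-fold lower number from compound 2 to compound 1 (0.21 log units; within the scatter) and on compound 3, which gives 22100 nM. Compound 4 is therefore estimated at 15000 nM, with a likely range from 7000 nM to 35000 nM.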

Compound 4, half-maximal inhibitory concentration: 18300 nM
Beside the measured number, compound 4's estimate is 1.2-fold (0.09 log units) below it, within the range that was stated.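

In this assay, hydrogen in place of methyl on an aromatic carbon gives a 1.2-fold lower number from compound 3 to compound 4 (0.08 log units; within the scatter), and this step agrees with the earlier one on the other core: the same change on two cores in this assay, a 1.6-fold lower number (0.21 log units; within the scatter) from compound 2 to compound 1 and a 1.2-fold lower number (0.08 log units; within the scatter) from compound 3 to compound 4, 1.4-fold (0.13 log units) apart, within the scatter of two such steps Likewise, (dimethylamino)methyl in place of dimethylamino gives a 1.0-fold lower number from compound 1 to compound 4 (0.01 log units; within the scatter), which agrees with its earlier counterpart: the same change on two cores in this assay, a 1.4-fold lower number (0.14 log units; within the scatter) from compound 2 to compound 3 and a 1.0-fold lower number (0.01 log units; within the scatter) from compound 1 to compound 4, 1.4-fold (0.13 log units) apart, within the scatter of two such steps Each change thus carries from one core to the other with no detectable dependence on the core, but all four steps lie within the scatter, so this does not show that either change has any effect on the read-out, and two cores offer only a narrow test of transfer.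

The compounds shown leave open how a chlorine or a methoxy group on that aromatic carbon would read in this assay. They also leave open whether a longer chain ending in dimethylamino, or a pyrrolidine in place of the dimethylamino group, would give a step beyond the scatter.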